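This account rests on a few compounds, and the source may have more. Where it says the series, first, only, none or still open, it means among the compounds named here.

Measured so far in a functional assay on A549 cells (Homo sapiens) for antiproliferative activity, read by MTT assay, with a stated time of 72 h; on this read-out higher numbers stand for weaker inhibition and lower numbers for stronger inhibition: compound 1 `CC/C=C\C(=O)Nc1cc(Nc2nccc(-c3cn(C)c4ccccc34)n2)c(OC)cc1N(C)CCN(C)C` gives 1530 nM; compound 2 `C=C(Cl)C(=O)Nc1cc(Nc2ncc(C#N)c(-c3cn(C)c4ccccc34)n2)c(OC)cc1N(C)CCN(C)C` gives 133 nM.

Compound 2 holds the lower of the two numbers in this assay, and its gap to compound 1 lies beyond the usual scatter, so compound 2 is the stronger inhibitor of the pair. Compound 3 `CC/C=C\C(=O)Nc1cc(Nc2ncc(C#N)c(-c3cn(C)c4ccccc34)n2)c(OC)cc1N(C)CCN(C)C` has not yet been run in this assay. It is reached from compound 2 by a single change, (but-1-en-1-yl in place of 1-chloroethenyl on a carbonyl carbon). Among the compounds with values here, no measured pair isolates this change, so its size cannot be read from the numbers in hand; only the values of compound 1 and compound 2 are available, and they differ at more than this one position. The working expectation is a moderate move toward weaker inhibition, with considerable uncertainty. Compound 3 is expected at about 400 nM, with a range of 130 nM to 1500 nM. The expected step of a 3.0-fold higher number from compound 2 to compound 3 (0.48 log units; beyond the scatter) is therefore toward a higher number, likely somewhat beyond the scatter.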

Compound 3, half-maximal inhibitory concentration: 162 nM
The estimate for compound 3 lay 2.5-fold (0.39 log units) above the measured number; measured number inside the range.
By their numbers in this assay, from the lowest: compounds 2 and 3 (each within the scatter of the next); then compound 1.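

In this assay, but-1-en-1-yl in place of 1-chloroethenyl on the carbonyl carbon gives a 1.2-fold higher number from compound 2 to compound 3 (0.09 log units; within the scatter), so with the cyano group present, this read-out does not separate these two groups. Cyano in place of hydrogen on an aromatic carbon, with but-1-en-1-yl kept on the carbonyl carbon, gives a 9.4-fold lower number from compound 1 to compound 3 (0.98 log units; beyond the scatter), which isolates this change for the first time and places the large step in this set at the cyano position rather than on the carbonyl carbon. The data offer no measured explanation for either step.

Still open, going by these compounds, is whether the cyano step holds with 1-chloroethenyl on the carbonyl carbon, and whether a chlorine or a trifluoromethyl group at the cyano position would match it. A plain ethenyl group or a dimethylamino-bearing chain on the carbonyl carbon also remains to be compared.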